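Replacing 3-(dimethylamino)propyl with pyridin-4-yl in compound 4

The source may hold more compounds than are shown below. What is called first, only, known or untested is meant among the compounds shown, and "the series" means these compounds.

In a functional assay on PC-3 cells (Homo sapiens) for inhibition, read by CellTiter-Glo, with a stated time of 72 h (on this read-out lower numbers stand for higher toxicity in this test and higher numbers for lower toxicity in this test), compound 3 `CC1=C(CC(=O)N2CCN(CCCN(C)C)CC2)c2cc(F)ccc2/C1=C\c1ccc([S+](C)[O-])cc1` gives only a limit of the assay, > 50000 nM, and no exact number. Compound 4 `CC1=C(CC(=O)N2CCN(c3ccncc3)CC2)c2cc(F)ccc2/C1=C\c1ccc([S+](C)[O-])cc1` carries pyridin-4-yl in place of 3-(dimethylamino)propyl on an amine nitrogen in a ring. Among the measured compounds shown here, only one measured step offers guidance, and it lies at a different place. Compound 1 `CC1=C(CC(=O)NCCN(C)C)c2cc(F)ccc2/C1=C\c1nc2ccccc2s1` gives 4880 nM, while compound 2 `CC1=C(CC(=O)NCCN(C)C)c2cc(F)ccc2/C1=C\c1ccncc1` gives 28900 nM. That is a 5.9-fold higher number from compound 1 to compound 2 (0.77 log units; beyond the scatter), a modest change on introducing pyridin-4-yl in place of 1,3-benzothiazol-2-yl. It is therefore only weak guidance, and a modest move to a lower number is expected here, as an at least 1.4-fold lower number from compound 3 to compound 4 (0.15 log units; that floor lies within the scatter). Compound 4 is estimated at 35000 nM, within an expected range of 12000 nM to 50000 nM.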

Compound 4, half-maximal cytotoxic concentration: 21900 nM
Beside the measured number, compound 4's estimate is 1.6-fold (0.20 log units) above it; low and high end bracket the measured number.
By their numbers in this assay, from the lowest: compound 1; then compounds 4 and 2 (each within the scatter of the next). At a limit, above all of these: compound 3.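

Replacing 3-(dimethylamino)propyl with pyridin-4-yl on an amine nitrogen in a ring gives an at least 2.2-fold lower number from compound 3 to compound 4 (0.35 log units; beyond the scatter) in this assay, so a change at this position can shift the read-out, which the earlier step, at a different place, could not show. Compound 3 gives only a limit, > 50000 nM. The full size of the step stays unknown because that value is a limit: the limit of > 50000 nM in this assay, at which 1 of the 4 values shown sits.

The compounds shown leave open how a phenyl group or a shorter 2-(dimethylamino)ethyl chain would behave on that nitrogen. It therefore remains unclear whether the aromatic ring or its nitrogen goes with the lower number.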